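The source may hold more compounds than are shown below. What is called first, only, known or untested is meant among the compounds shown, and "the series" means these compounds.

Compound 1 `COc1ccc2[nH]c(C(=O)N3CC(=O)N(Cc4ccccc4)[C@@H](CN4CCC(C)CC4)C3)cc2c1`: in a physicochemical assay for solubility, read by spectrophotometry, in phosphate buffer, with a stated time of 2 h, at pH 7.4 (on this read-out lower numbers stand for lower solubility and higher numbers for higher solubility), compound 1 gives 93100 nM.
Compound 2 `COc1ccc2[nH]c(C(=O)N3CC(=O)N(Cc4ccccc4)[C@@H](CN4CCC(OC)CC4)C3)cc2c1`: in this assay compound 2 gives > 25000 nM, which is a limit of the assay and not a number.

Compound 2 thus stands only at a limit, and a step that the limit leaves unreadable from compound 1 to compound 2 cannot be read because of the limit of > 25000 nM in this assay, at which 1 of the 2 values shown sits. Compound 3 `COc1ccc2[nH]c(C(=O)N3CC(=O)N(Cc4ccccc4)[C@@H](N4[C@H](C)CCC[C@@H]4C)C3)cc2c1` differs from compound 2 in one place: 2,6-dimethylpiperidin-1-yl in place of (4-methoxypiperidin-1-yl)methyl on a saturated ring carbon. No readable measured step bears on this change, so the expectation for compound 3 rests on the one number shown, that of compound 1. Compound 3 is estimated at 60000 nM, with a wide range from 15000 nM to 200000 nM. The expected step is a step that the limit leaves unreadable from compound 2 to compound 3.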

Compound 3, solubility: 100000 nM
For compound 3 the middle estimate is 1.7-fold (0.22 log units) below the measured one; low and high end bracket the measured number.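

In this assay, 2,6-dimethylpiperidin-1-yl in place of (4-methylpiperidin-1-yl)methyl on this saturated ring carbon gives a 1.1-fold higher number from compound 1 to compound 3 (0.03 log units; within the scatter). Going by these compounds alone, this is the first readable step at this position, and it shows that this exchange of one piperidine-bearing group for another leaves the read-out within the scatter. The step involving compound 2 cannot be read, and its value is a limit of the assay: the limit of > 25000 nM in this assay, at which 1 of the 3 values shown sits.

Still open, going by these compounds, is how a group of a different kind at this position, such as a carboxylic acid or a morpholine ring, would read in this assay.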